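Neopentyl in place of 1-methylcyclohexyl on a nucleoside core

This account rests on a few compounds, and the source may have more. Where it says the series, first, only, none or still open, it means among the compounds named here.

Compound 1 `CCCC(CCC)Nc1ncnc2c1ncn2C1O[C@H](CO)[C@@H](O)[C@H]1O`: 3.3 nM
Compound 2 `CC1(Nc2ncnc3c2ncn3C2O[C@H](CO)[C@@H](O)[C@H]2O)CCCCC1`: 70 nM
Compound 3 `CCCn1c(=O)c2nc(CC(C)(C)C)[nH]c2n(CCC)c1=O`: 49 nM

Of the compounds shown here, three have been measured in an assay on cell membranes for binding affinity to adenosine receptor A1 (Cavia porcellus), read by radioligand binding; a higher number here means a weaker inhibitor, a lower number a stronger inhibitor. Compound 2 gives the highest of the three numbers; compound 3 comes nearest to it, within the scatter, while compound 1 lies far lower. Within the data shown here, the one measured step that touches compound 2 is a 21-fold higher number from compound 1 to compound 2 (1.33 log units; beyond the scatter), in which 1-methylcyclohexyl takes the place of 1-propylbutyl on a nitrogen on an aromatic ring.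

Compound 4 `CC(C)(C)CNc1ncnc2c1ncn2C1O[C@H](CO)[C@@H](O)[C@H]1O` has not been measured. It differs from compound 2 as follows: neopentyl in place of 1-methylcyclohexyl on a nitrogen on an aromatic ring. The change sits at the same nitrogen at which the step from compound 1 to compound 2 acted, so that step is the only one bearing on it, and it was large. Among the measured compounds shown here, compound 3 carries a neopentyl as well, but on a different core, and no step joins it to compound 2; its value alone cannot be read across.

Compound 4 is expected to move back in the direction of compound 1, though not the whole way, because the step of a 21-fold higher number from compound 1 to compound 2 (1.33 log units; beyond the scatter) shows how much the group on this nitrogen can matter. The estimate for compound 4 is 30 nM, between 8 nM and 120 nM, a step of a 2.3-fold lower number from compound 2 to compound 4 (0.37 log units; beyond the scatter).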

Compound 4, inhibition constant: 17 nM
Compound 4: middle estimate off by 1.8-fold (0.25 log units), on the high side, within the range that was stated.
By their numbers in this assay, from the lowest: compound 1; then compound 4; then compounds 3 and 2 (each within the scatter of the next).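

In this assay, swapping the ring-bearing 1-methylcyclohexyl for the open neopentyl recovers part of the loss seen earlier at this nitrogen on an aromatic ring (in numbers, a 4.1-fold lower number from compound 2 to compound 4 (0.61 log units; beyond the scatter)). The recovery stops short of the 1-propylbutyl level (in numbers, a 5.2-fold higher number from compound 1 to compound 4 (0.71 log units; beyond the scatter)), so neopentyl does not simply restore what 1-propylbutyl gives. Among the three compounds on the shared core, the position now shows a graded order rather than a two-way split: 1-propylbutyl gives the lowest number, neopentyl an intermediate one and 1-methylcyclohexyl the highest, with each step beyond the scatter and the two groups without a ring both lower than the one with a ring. Nothing available bears on why the groups fall in this order.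

Three groups on one core cannot separate the effect of the ring from that of the branching, and a cyclopentyl ring or an unbranched butyl chain on the same nitrogen would be needed to pull these apart. Among these compounds, it also stays open how neopentyl behaves across cores, since compound 3 differs from compound 4 in more than one place and no step joins them.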